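Amide substituent series: cytotoxicity in monocytic cells

The compounds below may be only part of what the source reports. "The series", "measured", "known", "first", "only" and "open" are said of these compounds alone.

The compounds share the core of compound 1 `CCC(=O)Nc1ncc(-c2ccc(OC)cc2)n1C` and differ only in the group on the carbonyl carbon of the amide. In a toxicity assay on THP-1 cells (Homo sapiens) for inhibition (on this read-out higher numbers stand for lower toxicity in this test and lower numbers for higher toxicity in this test), compound 1 gives only a limit of the assay, > 100000 nM. Compound 2 `COc1ccc(-c2cnc(NC(=O)C3CCCCC3)n2C)cc1` carries cyclohexyl in place of ethyl on a carbonyl carbon. In this assay compound 2 likewise gives only a limit, > 100000 nM. The step that the two limits leave unreadable from compound 1 to compound 2 is therefore unreadable in size and direction, since both values sit at the limit of > 100000 nM in this assay, at which 2 of the 2 values shown sit. On the numbers shown, compound 2 stands at the limit, with no measured number to place it.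

Compound 3 `COc1ccc(-c2cnc(NC(=O)c3ccccn3)n2C)cc1` differs from compound 2 in one place: pyridin-2-yl in place of cyclohexyl on a carbonyl carbon. Within the data shown here, the single measured step touches the same position but gives no readable size, so nothing about direction or magnitude in this assay can be carried over from it. With both neighbours at the limit, no step beyond the scatter is expected. Compound 3 is expected to give about 100000 nM in this assay, within 30000 nM to 300000 nM. The estimated step is a number no higher from compound 2 to compound 3 (the limit leaves the size open).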

Compound 3, half-maximal cytotoxic concentration: > 100000 nM
Compound 3 gave a limit, no number (the forecaster's own chance of this, stated with the estimate: 75%); the middle value lies on the limit itself.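

No new step can be read among compound 1, compound 2 and compound 3 in this assay and all three values are limits of the assay: the limit of > 100000 nM in this assay, at which 3 of the 3 values shown sit.

The compounds shown leave open whether any group on the carbonyl carbon gives a measurable half-maximal cytotoxic concentration, and how the three compounds compare beyond that limit.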